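The source may hold more compounds than are shown below. What is called first, only, known or untested is meant among the compounds shown, and "the series" means these compounds.

Compound 1 `CCCn1c(SCc2cc([N+](=O)[O-])ccc2OC)nc2cc(NC(=O)NC(C)(C)C)ccc21` gives 18 nM in an assay on isolated protein for inhibition of Gonadotropin-releasing hormone receptor (Homo sapiens); on this read-out higher numbers stand for weaker inhibition and lower numbers for stronger inhibition. Compound 2 `CCCn1c(SCc2cc([N+](=O)[O-])ccc2OC)nc2cc(NC(=O)NC(C)(C)C)cc(C(=O)N(C)C)c21` carries a dimethylcarbamoyl group on an aromatic carbon of the shared core, and in this assay compound 2 gives 270 nM, a step of a 15-fold higher number from compound 1 to compound 2 (1.18 log units; beyond the scatter). Compound 3 `CCCn1c(SCc2cc([N+](=O)[O-])ccc2OC)nc2cc(NC(=O)NC(C)(C)C)cc(C(=O)NC(C)(C)C)c21` carries a (tert-butyl)carbamoyl group on that aromatic carbon, and in this assay compound 3 gives 410 nM, a step of a 23-fold higher number from compound 1 to compound 3 (1.36 log units; beyond the scatter). Between the two amides the step is a 1.5-fold higher number from compound 2 to compound 3 (0.18 log units; within the scatter). Compound 3 thus stands at the highest of the three numbers, close to compound 2 and far from compound 1.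

Compound 4 `CCCn1c(SCc2cc([N+](=O)[O-])ccc2OC)nc2cc(NC(=O)NC(C)(C)C)cc(C(=O)NCCCN(C)C)c21` differs from compound 3 by 3-(dimethylamino)propyl in place of tert-butyl on an amide-type nitrogen. The measured step that bears most directly on this change is the exchange on the carbonyl carbon, a 1.5-fold higher number from compound 2 to compound 3 (0.18 log units; within the scatter), which stayed within the scatter, whereas the large steps of a 15-fold higher number from compound 1 to compound 2 (1.18 log units; beyond the scatter) and a 23-fold higher number from compound 1 to compound 3 (1.36 log units; beyond the scatter) concern the introduction of the carbamoyl group itself, which compound 4 retains. Going by the values given here, with only one comparable exchange on hand, a step of a 1.2-fold lower number from compound 3 to compound 4 (0.07 log units; within the scatter) is expected, that is none beyond the scatter. Compound 4 is therefore estimated at 350 nM in this assay, with a range from 120 nM to 1000 nM.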

Compound 4, half-maximal inhibitory concentration: 170 nM
Beside the measured number, compound 4's estimate is 2.1-fold (0.31 log units) above it; the measured number falls inside the stated range.
By their numbers in this assay, from the lowest: compound 1; then compounds 4, 2 and 3 (each within the scatter of the next, the first and the last beyond it).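

At the amide-type nitrogen, the group carried there can move the number in this assay: 3-(dimethylamino)propyl in place of tert-butyl gives a 2.4-fold lower number from compound 3 to compound 4 (0.38 log units; beyond the scatter) and takes this exchange beyond the scatter, which the earlier comparison of the two amides had not done. The change does not hold against every amide, since the step of a 1.6-fold lower number from compound 2 to compound 4 (0.20 log units; within the scatter) stays within the scatter, and the chain does not remove the penalty of the carbamoyl group, with a 9.4-fold higher number from compound 1 to compound 4 (0.98 log units; beyond the scatter) still standing against the unsubstituted aromatic carbon. Nothing available here explains why this exchange moves the number.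

The compounds shown cannot separate the part played by the terminal dimethylamino group from that of the chain itself, as a plain propyl chain, a longer butyl chain or a propyl chain ending in a hydroxyl group would be needed to do so. Also open, as far as these compounds go, is whether any other group on this nitrogen, such as a morpholine-bearing chain or a carboxylic acid at the end of the chain, would bring the number closer to that of compound 1.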